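This account rests on a few compounds, and the source may have more. Where it says the series, first, only, none or still open, it means among the compounds named here.

Compound 3 `CCNC(=O)c1cc(Oc2ccc(NC(=O)c3cc4cccnc4n(-c4ccccc4F)c3=O)cc2)ccn1` is one of three compounds sharing the same core, differing only in the group on one amide nitrogen and in the aromatic ring carried on a ring nitrogen. In a functional assay on HT-29 cells (Homo sapiens) for antiproliferative activity, read by MTT assay, with a stated time of 72 h (a higher number here means a weaker inhibitor, a lower number a stronger inhibitor), compound 3 gives 260 nM. Compound 1 `CNC(=O)c1cc(Oc2ccc(NC(=O)c3cc4cccnc4n(-c4ccccc4F)c3=O)cc2)ccn1` gives 260 nM in this assay, and the two are level, since no change at the digits printed from compound 1 to compound 3 (within the scatter). Compound 2 `CNC(=O)c1cc(Oc2ccc(NC(=O)c3cc4cccnc4n(-c4ccc(OC)cc4)c3=O)cc2)ccn1` gives 920 nM, and the step of a 3.5-fold higher number from compound 1 to compound 2 (0.55 log units; beyond the scatter) sets it apart as the highest of the three numbers.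

Compound 4 `CCNC(=O)c1cc(Oc2ccc(NC(=O)c3cc4cccnc4n(-c4ccc(C(F)(F)F)cc4Cl)c3=O)cc2)ccn1` differs from compound 3 in a single place: 2-chloro-4-(trifluoromethyl)phenyl in place of 2-fluorophenyl on an aromatic nitrogen. Among the measured compounds shown here, the only measured step that touches this position is a 3.5-fold higher number from compound 1 to compound 2 (0.55 log units; beyond the scatter), which shows that swapping the aromatic ring on that nitrogen can shift the number beyond the scatter, though only by a modest amount. Compound 4 keeps a small group in the same part of the ring as the fluorine it replaces and adds a trifluoromethyl group further along, so a step of comparable size at most is expected, in either direction. The expected step is a 1.3-fold higher number from compound 3 to compound 4 (0.13 log units; within the scatter), with compound 4 estimated at 350 nM, within a range from 120 nM to 1000 nM.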

Compound 4, half-maximal inhibitory concentration: 4770 nM
Beside the measured number, compound 4's estimate is 14-fold (1.13 log units) below it; measured number above the stated range.
By their numbers in this assay, from the lowest: compounds 1 and 3 (each within the scatter of the next); then compound 2; then compound 4.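

In this assay, the step of an 18-fold higher number from compound 3 to compound 4 (1.26 log units; beyond the scatter) is large, whereas the earlier change of ring on this same aromatic nitrogen, a 3.5-fold higher number from compound 1 to compound 2 (0.55 log units; beyond the scatter), was modest. Among the compounds shown here, this position can therefore move the number much further than the earlier compounds showed, and a ring carrying a halogen at the 2-position does not guarantee a number close to that of compound 3. The entering and leaving groups both have zero hydrogen-bond donors and acceptors, and nothing available here explains the large step.

The 2-chloro-4-(trifluoromethyl)phenyl group brings in chlorine and trifluoromethyl together, so the contribution of each remains unresolved. Compounds carrying a 2-chlorophenyl or a 4-(trifluoromethyl)phenyl group on this nitrogen would separate the two, and a ring bearing an amine would show how a quite different substituent behaves here.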